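From compound 3 to compound 4: methoxy gives way to nitro

A few compounds are considered here, and "the series" means these few. Any claim that something is new, unique, unknown or untested is made for them only; others in the source may bear on it.

Three compounds sharing the core of compound 3 `COc1ccc(N2CCN(Cc3csc(N)c3C(=O)c3ccc(Cl)cc3)CC2)cc1` have been measured in a functional assay on CHO cells with adenosine receptor A1 (Homo sapiens) as the target, read by cAMP accumulation and immunoassay, with a stated time of 6 min, tested at 1 uM; on this read-out higher numbers stand for a weaker effect at the one concentration tested and lower numbers for a stronger effect. Compound 3 gives -15%, the highest of the three numbers. Compound 1 `Nc1scc(CN2CCN(c3ccc(F)cc3Cl)CC2)c1C(=O)c1ccc(Cl)cc1` gives -39%, and compound 2 `Nc1scc(CN2CCN(c3ccc(Cl)cc3F)CC2)c1C(=O)c1ccc(Cl)cc1` gives -57%. The step of a number 24 percentage points higher from compound 1 to compound 3 (beyond the scatter) and the step of a number 42 percentage points higher from compound 2 to compound 3 (beyond the scatter) both lie beyond the scatter, as does a number 18 percentage points lower from compound 1 to compound 2 (beyond the scatter); each of these three steps exchanges the whole aryl group on the amine nitrogen in the ring.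

Compound 4 `Nc1scc(CN2CCN(c3ccc([N+](=O)[O-])cc3)CC2)c1C(=O)c1ccc(Cl)cc1` differs from compound 3 by nitro in place of methoxy on an aromatic carbon. Among the measured compounds shown here, no measured step exchanges only one group on an aromatic carbon while leaving the rest of that ring as it is; the steps that exist replace the 4-methoxyphenyl by halogenated aryls, and each moved the read-out by a modest to large amount. They show that this part of the molecule does move the number, but they give no direction for a nitro group in particular. Compound 4 is therefore expected to give -25%, within a range from -55% to 5%. The expected step of a number 10 percentage points lower from compound 3 to compound 4 (within the scatter) is set small beside the measured ones, with the range kept wide.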

Compound 4, a percentage reported as activity, at one concentration (the size of the read-out at that concentration, not a potency): -8.3%
Compound 4: middle estimate off by 16.7 percentage points, on the low side, and the stated range covers the measured number.
By their numbers in this assay, from the lowest: compound 2; then compound 1; then compounds 3 and 4 (each within the scatter of the next).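

In this assay, among the compounds shown here, nitro in place of methoxy on an aromatic carbon, para to a large group, gives a number 6.7 percentage points higher from compound 3 to compound 4 (within the scatter); this is the first measured step that exchanges only one group on that ring, and it leaves the read-out within the scatter. The halogenated aryls stay clearly apart from the 4-nitrophenyl compound, with a number 48.7 percentage points higher from compound 2 to compound 4 (beyond the scatter) and a number 30.7 percentage points higher from compound 1 to compound 4 (beyond the scatter), both beyond the scatter and in the same direction as their steps to compound 3. Among these four compounds, the large differences therefore separate the two halogenated aryls from the 4-methoxyphenyl and 4-nitrophenyl groups, while the exchange of methoxy for nitro itself does not register.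

As far as these compounds go, it remains open whether a single chlorine or an amine at this same place would read with compound 3 and compound 4 or with the halogenated compound 1 and compound 2. Nothing available bears on why methoxy and nitro read alike here, or on why the halogenated aryls stand apart.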